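The compounds below may be only part of what the source reports. "The series", "measured", "known", "first", "only" and "open" are said of these compounds alone.

Compound 1, `CN(Cc1ccc2c(c1)OCCO2)c1cc(=O)c2cc(C(F)(F)F)cc([N+](=O)[O-])c2s1`: in an ADME assay on Vero cells (Chlorocebus sabaeus) for cytotoxicity, read by MTT assay, with a stated time of 48 h (a lower number here means a stronger inhibitor, a higher number a weaker inhibitor), compound 1 gives > 64 ug/mL, which is a limit of the assay.
Compound 2, `O=c1cc(NCc2ccccc2)sc2c([N+](=O)[O-])cc(C(F)(F)F)cc12`: in this assay compound 2 gives > 64 ug/mL, again a limit.
Compound 3, `COc1ccc(CN(C)c2cc(=O)c3cc(C(F)(F)F)cc([N+](=O)[O-])c3s2)cc1OC`: in this assay compound 3 gives > 64 ug/mL, also a limit.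

Within the data shown here, compound 3 therefore stands where every measured compound stands, at the limit of > 64 ug/mL in this assay, at which 3 of the 3 values shown sit, so no compound can be ranked against another. Among the measured compounds shown here, the only measured step, a step that the two limits leave unreadable from compound 1 to compound 3, is unreadable for the same reason. Compound 4, `CN(Cc1ccccc1)c1cc(=O)c2cc(C(F)(F)F)cc([N+](=O)[O-])c2s1`, differs from compound 3 by phenyl in place of 3,4-dimethoxyphenyl on a saturated chain carbon bound to a nitrogen on an aromatic ring. For the measured compounds named here, no measured step bears on this change, so the size of the step in this assay cannot be read from the data. It is nonetheless expected that compound 4 gives 100 ug/mL (range 40 ug/mL to 300 ug/mL), most likely reported again only as a limit. The expected step that the limit leaves unreadable from compound 3 to compound 4 is an estimate of no change beyond the scatter.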

Compound 4, half-maximal inhibitory concentration: > 64 ug/mL
Compound 4 ended at the assay's limit; the forecaster's own chance of this, stated with the estimate: 85%; the middle value is on the limit's open side.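

Compound 4 also sits at a limit, so its steps from compound 1, compound 2 and compound 3 cannot be read: the limit of > 64 ug/mL in this assay, at which 4 of the 4 values shown sit. The compounds shown leave open whether any of these changes alters the true values in this assay.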